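Acylating the ring nitrogen: from compound 2 to compound 4

The source may report more compounds than this note shows. Statements on the series, on what has been measured and on what is new or still open speak of the compounds shown alone.

Measured compounds:
- compound 1, `O=C(Nc1ccccc1O)C1CCc2ccccc2N1`, 5610 nM
- compound 2, `O=C(Nc1cc(C(F)(F)F)cc(C(F)(F)F)c1)C1CCc2ccccc2N1`, 8700 nM
- compound 3, `O=C(Nc1cc(C(F)(F)F)cc(C(F)(F)F)c1)C1CCc2ccccc2N1C(=O)c1cccc(Cl)c1`, 625 nM

In a functional assay on HCT-15 cells (Homo sapiens) for cytotoxicity, read by sulforhodamine B assay, with a stated time of 72 h (a lower number here means a stronger inhibitor of growth, a higher number a weaker inhibitor of growth), compound 1 and compound 2 give numbers within the scatter of each other; the difference between their two cores is not broken down here. Compound 3 carries the change ((3-chlorophenyl)carbonyl in place of hydrogen on a nitrogen on an aromatic ring in a ring), and the step of a 14-fold lower number from compound 2 to compound 3 (1.14 log units; beyond the scatter) is large. Compound 4, `O=C(Nc1ccccc1O)C1CCc2ccccc2N1C(=O)c1cccc(Cl)c1`, carries the same change on the core of compound 1, namely ((3-chlorophenyl)carbonyl in place of hydrogen on a nitrogen on an aromatic ring in a ring). Because the step of a 14-fold lower number from compound 2 to compound 3 (1.14 log units; beyond the scatter) was large, a step of similar size is expected for compound 4, estimated as a 9.4-fold lower number from compound 1 to compound 4 (0.97 log units; beyond the scatter). This rests on a single measured example, so the expected range is wide. Compound 4 is estimated at 600 nM, between 200 nM and 2000 nM.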

Compound 4, concentration for 50% growth inhibition: 23100 nM
Compound 4: middle estimate off by 39-fold (1.59 log units), on the low side; measured number outside the range, above it.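

In this assay, the same (3-chlorophenyl)carbonyl change on the core of compound 1 gives a 4.1-fold higher number from compound 1 to compound 4 (0.61 log units; beyond the scatter), a shift in the opposite direction to the one seen on the other core. The effect of this change therefore did not carry over from one core to the other: the same change on two cores in this assay, a 14-fold lower number (1.14 log units; beyond the scatter) from compound 2 to compound 3 and a 4.1-fold higher number (0.61 log units; beyond the scatter) from compound 1 to compound 4, 57-fold (1.76 log units) apart, beyond the scatter of two such steps

For the compounds shown here, with only two cores, this shows that the result of the change can depend on the core, but it does not show which part of the core matters or how other cores would respond. The compounds shown leave open whether the hydroxyl group or the two trifluoromethyl groups decide the direction of the step. They also leave open how an acetyl group or an unsubstituted benzoyl group would behave on either core.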